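A few compounds are considered here, and "the series" means these few. Any claim that something is new, unique, unknown or untested is made for them only; others in the source may bear on it.

Compound 1 `CC(C)[C@H](NC(=O)COc1cccc2ccccc12)C(=O)N[C@@H](CC(=O)O)C(=O)CSc1ncc[nH]1`, compound 2 `CC(C)[C@H](NC(=O)COc1cccc2ccccc12)C(=O)N[C@@H](CC(=O)O)C(=O)CSc1nnnn1C`, compound 3 `CC(C)[C@H](NC(=O)COc1cccc2ccccc12)C(=O)N[C@@H](CC(=O)O)C(=O)COc1cncc2ccccc12`.

In a functional assay on Jurkat cells (Homo sapiens) for inhibition (a lower number here means a stronger inhibitor, a higher number a weaker inhibitor), compound 1 gives > 200000 nM, a limit of the assay. In this assay compound 2 gives > 200000 nM, also a limit. In this assay, among the measured compounds shown here, compound 3 gives 166000 nM, the only number among the three, since the limit of > 200000 nM in this assay, at which 2 of the 3 values shown sit, marks where the other two sit.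

Compound 3 is reached by an at least 1.2-fold lower number from compound 1 to compound 3 (0.08 log units; that floor lies within the scatter) and by an at least 1.2-fold lower number from compound 2 to compound 3 (0.08 log units; that floor lies within the scatter), and neither floor lies beyond the scatter. Compound 4 `CC(C)[C@H](NC(=O)COc1cccc2ccccc12)C(=O)N[C@@H](CC(=O)O)C(=O)COn1nnc2ccccc2c1=O` differs from compound 3 by a group of 11 heavy atoms (7 carbon, 3 nitrogen, 1 oxygen; one six-membered aromatic ring of carbon only, one six-membered aromatic ring with 3 hetero atoms) in place of a group of 10 heavy atoms (9 carbon, 1 nitrogen; one six-membered aromatic ring of carbon only, one six-membered aromatic ring with 1 hetero atom), on an oxygen on a saturated carbon. For the measured compounds named here, no measured step exchanges the group on that oxygen, so only the two steps from the limits bear on it, and they show compound 3 sitting close to the limit itself. For compound 4 a step of a 1.1-fold higher number from compound 3 to compound 4 (0.04 log units; within the scatter) is expected, with a real chance of another limit. Compound 4 is therefore estimated at 180000 nM, with a range from 60000 nM to 500000 nM.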

Compound 4, half-maximal inhibitory concentration: 137000 nM
For compound 4 the middle estimate is 1.3-fold (0.12 log units) above the measured one; the range from low to high includes it.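

In this assay, among the compounds shown here, the first measured exchange on this oxygen, from isoquinolin-4-yl to the group with one six-membered aromatic ring with 3 hetero atoms, gives a 1.2-fold lower number from compound 3 to compound 4 (0.08 log units; within the scatter), so these two quite different groups cannot be told apart. The floors against the sulfur-linked groups, an at least 1.4-fold lower number from compound 2 to compound 4 (0.16 log units; that floor lies within the scatter) and an at least 1.4-fold lower number from compound 1 to compound 4 (0.16 log units; that floor lies within the scatter), also stay within the scatter. Compound 1 and compound 2 each remain at a limit of the assay: the limit of > 200000 nM in this assay, at which 2 of the 4 values shown sit.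

On these data alone, whether another group on that oxygen, such as a plain phenyl or a longer chain bearing an amine, would move the number beyond the scatter remains open. The compounds shown also leave open whether any change outside that group would do so.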